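Bromo to ethyl on the core of compound 2

The source may hold more compounds than are shown below. What is called first, only, known or untested is meant among the compounds shown, and "the series" means these compounds.

Compound 1 `O=C(NCCCNc1nc(Nc2cccc(F)c2)ncc1Br)c1cccs1` gives 9 nM in an assay on isolated protein for inhibition of serine/threonine-protein kinase TBK1 (Homo sapiens); on this read-out lower numbers stand for stronger inhibition and higher numbers for weaker inhibition. Compound 2 `O=C(NCCCNc1nc(Nc2cccc(F)c2)ncc1Br)C1CCC1` gives 2 nM. Compound 3 `CC(=O)N1CCC(C(=O)NCCCNc2nc(Nc3cccc(F)c3)ncc2Br)CC1` gives 430 nM.

Compound 2 stands at the lowest number of the three; the nearest is compound 1, separated by a 4.5-fold lower number from compound 1 to compound 2 (0.65 log units; beyond the scatter), and the furthest is compound 3, separated by a 220-fold higher number from compound 2 to compound 3 (2.33 log units; beyond the scatter). Compound 1 and compound 3 differ by a 48-fold higher number from compound 1 to compound 3 (1.68 log units; beyond the scatter). Every one of these steps changes the group on the carbonyl carbon and leaves the rest of the shared core untouched.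

Compound 4 `CCc1cnc(Nc2cccc(F)c2)nc1NCCCNC(=O)C1CCC1` keeps the cyclobutyl group on the carbonyl carbon and changes the core instead: ethyl in place of bromo on an aromatic carbon. Going by the values given here, no measured step touches that position, so the three steps above, one modest and two large, give no direct guide; they show only that this series can move strongly with a single change. Without a comparable step, a loss beyond the scatter is expected to be possible but not large. The step from compound 2 to compound 4 in this assay is estimated at a 3.0-fold higher number from compound 2 to compound 4 (0.48 log units; beyond the scatter). Compound 4 is therefore expected to give about 6 nM, within a range from 1.5 nM to 25 nM.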

Compound 4, half-maximal inhibitory concentration: 63 nM
Compound 4: middle estimate off by 11-fold (1.02 log units), on the low side; the whole stated range lies below it.
By their numbers in this assay, from the lowest: compound 2; then compound 1; then compound 4; then compound 3.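

In this assay the exchange of bromo for ethyl on the aromatic carbon gives a 32-fold higher number from compound 2 to compound 4 (1.50 log units; beyond the scatter) and so shows that this position of the shared core, ortho to a large group and para to a (3-fluorophenyl)amino group, also moves the number strongly, whereas the earlier steps had shown this only for the group on the carbonyl carbon. The change is small on the counts: 1 heavy atom leaves and 2 heavy atoms enter, with no ring, no hydrogen-bond donor or acceptor and no net charge on either side, so a large step here does not depend on any of these counted features changing. Nothing measured here explains the loss at this position.

The compounds shown leave open whether other groups at this position, such as chloro, methyl or a nitrile, would stay close to bromo or fall away as ethyl does. They also leave open whether the same exchange carries the same weight with thiophen-2-yl or 1-acetylpiperidin-4-yl on the carbonyl carbon in place of cyclobutyl.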